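Swapping the carbamate amine in a trimethoxybenzoyl piperazine

The compounds below may be only part of what the source reports. "The series", "measured", "known", "first", "only" and "open" are said of these compounds alone.

Compound 1 `CCC(CC)C(=O)OCC1CN(C(=O)c2cc(OC)c(OC)c(OC)c2)CCN1C(=O)c1cc(OC)c(OC)c(OC)c1`: 250 nM; 90 nM; 220 nM (3 entries)
Compound 2 `COc1cc(C(=O)N2CCN(C(=O)c3cc(OC)c(OC)c(OC)c3)C(COC(=O)NC(C)C(C)C)C2)cc(OC)c1OC`: 70 nM

Going by the values given here, both measured compounds share the same core; in an assay (Oryctolagus cuniculus) for binding affinity to platelet-activating factor receptor (Cavia porcellus) (a higher number here means that more compound is needed for the effect, a lower number that less compound is needed), compound 2 gives 70 nM, the only number it has, while compound 1 shows (the several entries of compound 1 in this assay, 250 nM; 90 nM; 220 nM (3 entries)). Compound 3 `CCCN(CCC)C(=O)OCC1CN(C(=O)c2cc(OC)c(OC)c(OC)c2)CCN1C(=O)c1cc(OC)c(OC)c(OC)c1` has not yet been measured in this assay. It differs from compound 2 by dipropylamino in place of (1,2-dimethylpropyl)amino on a carbonyl carbon. Among the compounds with values here, with no comparable step among the measured compounds, the expected step of a 1.9-fold higher number from compound 2 to compound 3 (0.27 log units; within the scatter) is small, in either direction and hardly beyond the scatter. Compound 3 is therefore expected to give about 130 nM, between 40 nM and 450 nM.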

Compound 3, half-maximal effective concentration: 680 nM
Estimate against measurement, compound 3: 5.2-fold (0.72 log units) below; the whole stated range lies below it.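

Changing the amine on this carbamate carbonyl is not neutral: in this assay the swap gives a 9.7-fold higher number from compound 2 to compound 3 (0.99 log units; beyond the scatter). The change removes the one hydrogen-bond donor of (1,2-dimethylpropyl)amino and also replaces its branched chain with two propyl chains, and this single pair cannot separate those differences. The step can be set against the spread of repeated entries for one compound: the several entries of compound 1 in this assay, 250 nM; 90 nM; 220 nM (3 entries).

Still open, from the compounds shown here alone, is which difference matters. Propylamino would keep the donor with one propyl chain, while methyl(propyl)amino would have no donor.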